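The source may hold more compounds than are shown below. What is called first, only, known or untested is meant among the compounds shown, and "the series" means these compounds.

Compound 2 `Clc1ccc(N2CC[C@H]3CN[C@H]3C2)cn1` is the stronger of the two measured compounds in a functional assay on HEK293 cells for agonist activity at Neuronal acetylcholine receptor; alpha4/beta2 (Homo sapiens), read by FLIPR (a lower number here means that less compound is needed, a higher number that more compound is needed for the effect), where compound 2 gives 13 nM. For the measured compounds named here, compound 1 `c1cncc(N2CC[C@H]3CN[C@H]3C2)c1` gives 71 nM in this assay, and the only measured step, a 5.5-fold lower number from compound 1 to compound 2 (0.74 log units; beyond the scatter), came with chloro in place of hydrogen. Compound 3 `Cc1cc(N2CC[C@H]3CN[C@H]3C2)cnc1Cl` differs from compound 2 by methyl in place of hydrogen on an aromatic carbon. Going by the values given here, no measured step concerns a methyl, so the chloro step gives no direct guide, and no change beyond the scatter is expected. Compound 3 is expected to give 12 nM in this assay, between 4 nM and 40 nM. The expected step is a 1.1-fold lower number from compound 2 to compound 3 (0.03 log units; within the scatter).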

Compound 3, half-maximal effective concentration: 7.2 nM
Compound 3: middle estimate off by 1.7-fold (0.22 log units), on the high side; the measured number falls inside the stated range.
By their numbers in this assay, from the lowest: compounds 3 and 2 (each within the scatter of the next); then compound 1.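

At the ring position ortho to the chloro group and two atoms from the ring nitrogen, a methyl is tolerated in this assay, with a 1.8-fold lower number from compound 2 to compound 3 (0.26 log units; within the scatter). For the compounds shown here, this is the first measured change at this position, and the added carbon leaves the number within the scatter. No evidence is available that bears on this result.

On these data alone, whether an ethyl, a methoxy or an amine at this position would also hold the number remains open. So does whether a methyl here would behave the same way without the chloro group.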